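The source may hold more compounds than are shown below. What is called first, only, known or untested is meant among the compounds shown, and "the series" means these compounds.

In a functional assay on MCF7 cells (Homo sapiens) for cytotoxicity, read by WST assay, with a stated time of 72 h (on this read-out higher numbers stand for weaker inhibition and lower numbers for stronger inhibition), compound 1 (`O=C1Nc2c(ccc(F)c2F)C1(c1ccccc1)c1ccc(O)cc1`) gives 7.1 nM and compound 2 (`O=C1Nc2c(ccc(F)c2F)C1(c1ccc(O)cc1)c1ccc(F)c(F)c1`) gives 7.8 nM. For the measured compounds named here, compound 2 therefore stands level with compound 1, the only other compound measured so far, and the change between them, a 1.1-fold higher number from compound 1 to compound 2 (0.04 log units; within the scatter), gives no basis for ranking the pair.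

The next compound is compound 3 (`O=C1Nc2c(ccc(F)c2F)C1(c1ccc(O)cc1)c1cccnc1`), which has pyridin-3-yl in place of 3,4-difluorophenyl on a saturated ring carbon. Going by the values given here, only one measured step bears on this change. It concerns the same place, and it is small: a 1.1-fold higher number from compound 1 to compound 2 (0.04 log units; within the scatter). That step shows that phenyl and 3,4-difluorophenyl read alike there, but neither measured compound carries a hetero atom in that ring, so the data do not test the new group directly. A modest shift towards a higher number in this assay is expected, though a result within the scatter would be no surprise. The expected change is a 1.8-fold higher number from compound 2 to compound 3 (0.25 log units; within the scatter). Compound 3 is estimated at 14 nM, with an expected range of 5 nM to 50 nM.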

Compound 3, half-maximal inhibitory concentration: 63 nM
The estimate for compound 3 lay 4.5-fold (0.65 log units) below the measured number; the measured number lies above the stated range.
By their numbers in this assay, from the lowest: compounds 1 and 2 (each within the scatter of the next); then compound 3.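

In this assay, the group on the saturated ring carbon turns out to matter: pyridin-3-yl gives an 8.1-fold higher number from compound 2 to compound 3 (0.91 log units; beyond the scatter), and the same group gives an 8.9-fold higher number from compound 1 to compound 3 (0.95 log units; beyond the scatter), both beyond the scatter. The earlier pair, with a 1.1-fold higher number from compound 1 to compound 2 (0.04 log units; within the scatter), had shown only that two aromatic rings of carbon alone read alike at this position, so it could not reveal that a ring with a hetero atom would part from them. Among these three compounds, the two carbon-only rings stand together and the ring with a hetero atom gives the higher number, with no compound going against that division, but nothing available here accounts for the shift.

What the compounds shown leave open is whether this shift belongs to pyridin-3-yl alone or would also appear with pyridin-2-yl or pyridin-4-yl. On these data alone, it is also open whether a phenyl ring carrying an amine or a carboxylic acid would read with the carbon-only rings of compound 1 and compound 2 or with compound 3.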